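A few compounds are considered here, and "the series" means these few. Any claim that something is new, unique, unknown or untested is made for them only; others in the source may bear on it.

Compound 1 `CCOC(=O)C1CCN(S(=O)(=O)c2ccc(S(=O)(=O)N(CC)CC)cc2)CC1`: 23100 nM
Compound 2 `CCCN(CCC)S(=O)(=O)c1ccc(S(=O)(=O)N2CCC[C@@H](C(=O)OCC)C2)cc1`: 2500 nM
Compound 3 `CCOC(=O)[C@@H]1CCCN(S(=O)(=O)c2ccc(S(=O)(=O)N3CCOCC3)cc2)C1`: 23400 nM

These numbers come from a functional assay on BXPC-3 cells (Homo sapiens) for inhibition, read by MTT assay, with a stated time of 7 days; on this read-out lower numbers stand for stronger inhibition and higher numbers for weaker inhibition. Compound 3 gives the highest number of the three, the weakest inhibition; compound 1 lies within the scatter of it, while compound 2 gives a clearly lower number. Within the data shown here, the only single-point step that can be followed, a 9.4-fold higher number from compound 2 to compound 3 (0.97 log units; beyond the scatter), changes the group on the same sulfonyl sulfur.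

Compound 4 `CCOC(=O)[C@@H]1CCCN(S(=O)(=O)c2ccc(S(=O)(=O)N3CCCCC3)cc2)C1` differs from compound 3 by piperidin-1-yl in place of morpholin-4-yl on a sulfonyl sulfur. Piperidin-1-yl is closer to morpholin-4-yl than dipropylamino is, so a lower number is expected, but a smaller move than that step. Compound 4 is therefore estimated at 7000 nM, with a range from 2500 nM to 20000 nM, an expected step of a 3.3-fold lower number from compound 3 to compound 4 (0.52 log units; beyond the scatter).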

Compound 4, half-maximal inhibitory concentration: 3300 nM
Compound 4: middle estimate off by 2.1-fold (0.33 log units), on the high side, within the range that was stated.
By their numbers in this assay, from the lowest: compounds 2 and 4 (each within the scatter of the next); then compounds 1 and 3 (each within the scatter of the next).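

Exchanging morpholin-4-yl for piperidin-1-yl on the sulfonyl sulfur replaces one ring oxygen with carbon in a ring of the same size, and this alone gives a 7.1-fold lower number from compound 3 to compound 4 (0.85 log units; beyond the scatter). The comparison with the open-chain group gives a 1.3-fold higher number from compound 2 to compound 4 (0.12 log units; within the scatter), so piperidin-1-yl and dipropylamino cannot be told apart here, and among these three groups only morpholin-4-yl gives the weaker inhibition. Nothing available explains the effect of that ring oxygen. Going by these compounds, it remains open whether piperazin-1-yl or the smaller pyrrolidin-1-yl would keep the lower number.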